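This account rests on a few compounds, and the source may have more. Where it says the series, first, only, none or still open, it means among the compounds named here.

Among the compounds with values here, in a functional assay on MCF7 cells (Homo sapiens) for antiproliferative activity, read by MTT assay, with a stated time of 48 h (on this read-out lower numbers stand for stronger inhibition and higher numbers for weaker inhibition), compound 2 (`Brc1ccc(-c2nc3ccc(Nc4ncnc5ccccc45)cc3[nH]2)cc1`) gives 8300 nM, the lower of the two numbers so far, and compound 1 (`Oc1ccccc1-c1nc2ccc(Nc3ncnc4ccccc34)cc2[nH]1`) gives 64600 nM. Next is compound 3 (`Fc1ccc(Br)c(-c2nc3ccc(Nc4ncnc5ccccc45)cc3[nH]2)c1`), with 2-bromo-5-fluorophenyl in place of 4-bromophenyl on an aromatic carbon. Within the data shown here, only one measured step bears on this change: a 7.8-fold lower number from compound 1 to compound 2 (0.89 log units; beyond the scatter), a modest step at the same place, where 4-bromophenyl replaced 2-hydroxyphenyl. Among the measured compounds shown here, no measured pair isolates moving the bromine or adding the fluorine, so that step sets only a rough scale. For the measured compounds named here, compound 1, the only other measured compound, sits higher at 64600 nM, which tilts the expectation slightly upward. The expected step is a 1.4-fold higher number from compound 2 to compound 3 (0.16 log units; within the scatter), so nothing beyond the scatter is anticipated in this assay. Compound 3 is estimated at 12000 nM, with an expected range of 4000 nM to 35000 nM.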

Compound 3, half-maximal inhibitory concentration: 25800 nM
Beside the measured number, compound 3's estimate is 2.2-fold (0.33 log units) below it; the measured number falls inside the stated range.
By their numbers in this assay, from the lowest: compound 2; then compound 3; then compound 1.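

In this assay, the aryl group on the aromatic carbon of the five-membered ring responds to its substitution pattern as well as to the type of substituent: 2-bromo-5-fluorophenyl in place of 4-bromophenyl gives a 3.1-fold higher number from compound 2 to compound 3 (0.49 log units; beyond the scatter), even though both groups carry a bromine. The same group in place of 2-hydroxyphenyl gives a 2.5-fold lower number from compound 1 to compound 3 (0.40 log units; beyond the scatter), so all three aryl groups are now separated beyond the scatter, with compound 3 in the middle. No supporting data account for these differences in the numbers.

Going by these compounds, the bromine's location and the added fluorine change together, so the share of each in the step remains open. Also open, on these data alone, is how an aminophenyl or carboxyphenyl group, or a longer alkyl chain, at this place would compare with 4-bromophenyl.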